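The compounds below may be only part of what the source reports. "The series", "measured", "known", "first", "only" and "open" are said of these compounds alone.

Measured so far in a physicochemical assay for lipophilicity, read by HPLC, measured as chromatographic lipophilicity; a lower number here means a more polar compound, a higher number a more lipophilic compound:
compound 1 `CCC/N=C1\S/C(=C\c2ccc(C(=O)O)cc2)C(=O)N1c1ccccc1C` gives 1 
compound 2 `CCC/N=C1\S/C(=C\c2ccc(C(=O)OCCO)cc2)C(=O)N1c1ccccc1C` gives 3.4 
compound 3 `CCC/N=C1\S/C(=C\c2ccc(C(=O)OCCCO)cc2)C(=O)N1c1ccccc1O` gives 2.3 

Compound 3 (2.3) stands second highest of the three. The highest number belongs to compound 2 (3.4). The lowest number belongs to compound 1 (1). Both gaps from compound 3 lie beyond the scatter. The next compound, compound 4 `CCC/N=C1\S/C(=C\c2ccc(C(=O)OCc3oc(=O)oc3C)cc2)C(=O)N1c1ccccc1O`, differs from compound 3 in one place: a group of 7 heavy atoms (4 carbon, 3 oxygen; one five-membered aromatic ring with 2 hetero atoms) in place of a group of 3 heavy atoms (2 carbon, 1 oxygen; no ring), on a saturated chain carbon bound to an oxygen next to a carbonyl group is the whole change, and the rest of the structure stays the same.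

Within the data shown here, only one measured step offers any guide, and it is a loose one. The step of a number 2.40 log units higher from compound 1 to compound 2 (beyond the scatter) is large, but it replaces hydrogen, whereas compound 3 and compound 4 both carry a group on that oxygen. Among the measured compounds shown here, no measured step exchanges one such group for another. For the measured compounds named here, with the step of a number 2.40 log units higher from compound 1 to compound 2 (beyond the scatter) as the only guide, a much smaller rise is expected here in this assay and its size remains uncertain. An estimated a number 0.70 log units higher from compound 3 to compound 4 (beyond the scatter) is expected on this reading. Compound 4 is estimated at 3 with an expected range of 2.4 to 3.6 in this assay.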

Compound 4, distribution coefficient: 3.3
For compound 4 the middle estimate is 0.30 log units below the measured one, and the stated range covers the measured number.
By their numbers in this assay, from the lowest: compound 1; then compound 3; then compounds 4 and 2 (each within the scatter of the next).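

Working from this assay, the place on a saturated chain carbon bound to an oxygen next to a carbonyl group still responds when one group is exchanged for another, not only when a group replaces hydrogen: a number 1.00 log units higher from compound 3 to compound 4 (beyond the scatter). The change bundles several differences, since the entering group brings a five-membered aromatic ring, more heavy atoms, no hydrogen-bond donors and more hydrogen-bond acceptors, so this single step cannot assign the rise to any one of them. No supporting measurement bears on the origin of this rise.

The compounds shown leave open how a plain ethyl chain or a phenyl ring would read at this place, which would separate the effect of the ring from that of the terminal hydroxyl. From the compounds shown here alone, whether the same exchange gives a similar step on the core of compound 1 also remains open.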